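Ester to amide at the carbonyl: cytotoxicity outlook

The source may report more compounds than this note shows. Statements on the series, on what has been measured and on what is new or still open speak of the compounds shown alone.

Compound 2 `O=C(OCc1ccc(Cl)cc1)c1cc(-c2ccccc2)nc2ccccc12` gives in an ADME assay on HepG2 2.2.15 cells (Homo sapiens) for cytotoxicity, read by MTT assay, with stated times of 3 days and 7 days (on this read-out higher numbers stand for lower toxicity in this test and lower numbers for higher toxicity in this test), only a limit, > 20000 nM. Compound 1 `Cc1ccc(-c2cc(C(=O)N3CCC(Cc4ccccc4)CC3)c3ccccc3n2)cc1` likewise gives in this assay a limit, > 20000 nM. Both values sit at the limit of > 20000 nM in this assay, at which 2 of the 2 values shown sit, so no number for compound 2 is known. Compound 3 `O=C(NCc1ccc(Cl)cc1)c1cc(-c2ccccc2)nc2ccccc12` differs from compound 2 by (4-chlorobenzyl)amino in place of (4-chlorobenzyl)oxy on a carbonyl carbon. Within the data shown here, no measured pair of this kind exists; no change beyond the scatter is expected in this assay, and compound 3 is expected to stay at the limit. The estimate for compound 3 in this assay is 30000 nM, range 15000 nM to 60000 nM. The expected step is a step that the limit leaves unreadable from compound 2 to compound 3.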

Compound 3, half-maximal cytotoxic concentration: > 20000 nM
Compound 3 ended at the assay's limit (the forecaster's own chance of this, stated with the estimate: 85%); the middle value does not contradict the limit.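

No step can be read from compound 2 to compound 3, as both values are limits: the limit of > 20000 nM in this assay, at which 3 of the 3 values shown sit.

The compounds shown leave open whether (4-chlorobenzyl)amino and (4-chlorobenzyl)oxy on the carbonyl carbon differ at all in cytotoxicity.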